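Clearance after a ring swap on the shared core

The source may report more compounds than this note shows. Statements on the series, on what has been measured and on what is new or still open speak of the compounds shown alone.

Compound 1 `CCN(C(=O)OC)c1c(N)nc(-c2nn(Cc3ccccc3F)c3ncccc23)nc1N`: 11.7 mL/min/kg
Compound 2 `Nc1nc(-c2nn(Cc3ccccc3F)c3ncccc23)nc(N)c1NC(=O)OC1COC1`: 1.67 mL/min/kg

Both numbers come from an ADME assay on cells (Hepatocyte, Rattus norvegicus) for pharmacokinetics, read by LC-MS, with a stated time of 90 min, tested at 1 uM (on this read-out higher numbers stand for fast clearance and lower numbers for slow clearance), where compound 2 stands lowest, at 1.67 mL/min/kg. The next structure, compound 3 `Nc1nc(-c2nn(Cc3ccccc3F)c3ncccc23)nc(N)c1N1C[C@@H](C(F)(F)F)OC1=O`, has not yet been measured. It carries 2-oxo-5-(trifluoromethyl)-1,3-oxazolidin-3-yl in place of (((oxetan-3-yl)oxy)carbonyl)amino on an aromatic carbon. Going by the values given here, one measured step bears on this change: a 7.0-fold lower number from compound 1 to compound 2 (0.85 log units; beyond the scatter). The entering group resembles the ethyl(methoxycarbonyl)amino of compound 1, at 11.7 mL/min/kg, in having no hydrogen on its nitrogen, so part of that step may reverse. Among the compounds with values here, the trifluoromethyl group has no measured precedent here. In this assay, a modest rise is therefore expected: a 2.1-fold higher number from compound 2 to compound 3 (0.32 log units; beyond the scatter). The estimated value for compound 3 is 3.5 mL/min/kg, with an expected range from 1.3 mL/min/kg to 10 mL/min/kg.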

Compound 3, clearance: 26.7 mL/min/kg
Estimate against measurement, compound 3: 7.6-fold (0.88 log units) below; the measured number lies above the stated range.
By their numbers in this assay, from the lowest: compound 2; then compound 1; then compound 3.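

In this assay this position on the shared core proves highly sensitive: 2-oxo-5-(trifluoromethyl)-1,3-oxazolidin-3-yl in place of (((oxetan-3-yl)oxy)carbonyl)amino gives a 16-fold higher number from compound 2 to compound 3 (1.20 log units; beyond the scatter) and more than cancels the earlier gain. The ring also goes past the open-chain ethyl(methoxycarbonyl)amino, with a 2.3-fold higher number from compound 1 to compound 3 (0.36 log units; beyond the scatter) on the same read-out, so the new compound is the fastest cleared of the three. Across these three compounds, the two without a hydrogen on the nitrogen at this position give the higher numbers and none goes against that pattern, though three compounds are a thin basis.

No measurement at hand explains the rise. From the compounds shown here alone, how the plain 2-oxo-1,3-oxazolidin-3-yl ring without trifluoromethyl would read remains open, so the shares of the ring and of the trifluoromethyl group cannot be told apart.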